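The source may hold more compounds than are shown below. What is called first, only, known or untested is meant among the compounds shown, and "the series" means these compounds.

In an ADME assay on MT4 cells (Homo sapiens) for cytotoxicity, read by MTT assay, with a stated time of 3 days (a lower number here means that less compound is tolerated, a higher number that more compound is tolerated), compound 1 `CC(C)(NC(=O)COC(=O)c1ccc([N+](=O)[O-])o1)c1ccccc1` gives > 100000 nM as a limit of the assay and not a number. Compound 2 `CC(C)(C)N(CCCc1ccccc1)C(=O)COC(=O)c1ccc([N+](=O)[O-])o1` is reported as "not active" (no number reported) with no number attached, so it offers no single value in this assay as a starting point. Compound 3 `CC(=O)Oc1ccccc1CN(C(=O)COC(=O)c1ccc([N+](=O)[O-])o1)C(C)(C)C` is still to be measured. The structural change is 2-acetoxyphenyl in place of phenethyl on a saturated chain carbon bound to an amide-type nitrogen and amounts to 2-acetoxyphenyl in place of phenethyl on a saturated chain carbon bound to an amide-type nitrogen. Among the measured compounds shown here, no measured step is available, and the only numerical guide comes from compound 1 with the limit of > 100000 nM in this assay, at which 1 of the 2 values shown sits, as its entry. In this assay a step no larger than the usual scatter is expected for this change, and any move would be toward less compound tolerated. Compound 3 is estimated at 70000 nM with an expected range from 20000 nM to 100000 nM and may well turn out to be only a limit.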

Compound 3, half-maximal cytotoxic concentration: > 100000 nM
Compound 3: only a limit was reported; the forecaster's own chance of this, stated with the estimate: 60%; middle value at least 1.4-fold (0.15 log units) away from the limit.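

No step can be read from compound 2 to compound 3, as compound 2 has no number in this assay. Compound 3 gives > 100000 nM, a limit and not a number. The compounds shown leave open whether 2-acetoxyphenyl in place of phenethyl changes the result in this assay at all.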